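Swapping a Chloro for a Methoxy on the Lactam Ring

The compounds below may be only part of what the source reports. "The series", "measured", "known", "first", "only" and "open" are said of these compounds alone.

Measured compounds in a functional assay on cells (Melanoma cell, Homo sapiens) for cytotoxicity, with a stated time of 48 h; a lower number here means a stronger inhibitor of growth, a higher number a weaker inhibitor of growth:
- compound 1 `O=C1/C(=C/c2c(Cl)[nH]c3ccccc23)c2ccccc2N1Cc1ccccc1` gives 61700 nM
- compound 2 `COc1c(/C=C2/C(=O)Nc3ccccc32)c2ccccc2n1-c1ccccc1` gives 3980 nM
- compound 3 `COc1c(/C=C2/C(=O)Nc3ccc(Cl)cc32)c2ccccc2n1-c1ccccc1` gives 18200 nM

Compound 3 has the second highest number of the three, so it inhibits growth less strongly than compound 2 and more strongly than compound 1. Compound 4 `COc1ccc2c(c1)/C(=C\c1c(OC)n(-c3ccccc3)c3ccccc13)C(=O)N2` differs from compound 3 in one place: methoxy in place of chloro on an aromatic carbon. For the measured compounds named here, the only measured step touching this position is a 4.6-fold higher number from compound 2 to compound 3 (0.66 log units; beyond the scatter), where adding a chloro weakened growth inhibition. Going by these compounds, no methoxy at this position has been measured, so its effect is unknown; it could behave like the chloro or fall back toward compound 2. The estimate for compound 4 is therefore 10000 nM, with a range of 3000 nM to 40000 nM, expected as a 1.8-fold lower number from compound 3 to compound 4 (0.26 log units; within the scatter).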

Compound 4, concentration for total growth inhibition: 17000 nM
Estimate against measurement, compound 4: 1.7-fold (0.23 log units) below; the measured number falls inside the stated range.
By their numbers in this assay, from the lowest: compound 2; then compounds 4 and 3 (each within the scatter of the next); then compound 1.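

In this assay the change from chloro to methoxy gives a 1.1-fold lower number from compound 3 to compound 4 (0.03 log units; within the scatter) and so makes no readable difference at this position. Methoxy in place of hydrogen gives a 4.3-fold higher number from compound 2 to compound 4 (0.63 log units; beyond the scatter) and thus weakens growth inhibition, which shows that the loss seen earlier is not confined to chloro. No measurement shown here explains why either group weakens growth inhibition.

Going by these compounds, whether every group at this position weakens growth inhibition remains open. A fluoro, an amine or a carboxylic acid there could test this, and each could either match compound 2 or fall with compounds 3 and 4.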